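Amine-ether series: methyl ester in place of the acid

The compounds below may be only part of what the source reports. "The series", "measured", "known", "first", "only" and "open" are said of these compounds alone.

Working notes on the aryl ether amines tested in a functional assay on SK-OV-3 cells (Homo sapiens) for inhibition, read by CCK-8 assay, with a stated time of 70 h; a lower number here means a stronger inhibitor, a higher number a weaker inhibitor. Compound 1 `O=C(O)c1cccc(COc2ccc(OCCOCCNC3CCCC3)cc2)c1` carries a free carboxylic acid on its terminal ring. In this assay compound 1 gives > 100000 nM, which is a limit of the assay and not a number; this is the limit of > 100000 nM in this assay, at which 1 of the 2 values shown sits, so compound 1 sits at the edge of what the assay can report. Compound 2 `c1ccc(COc2ccc(COc3ccc(OCCOCCNC4CCCCC4)cc3)cc2)cc1`, the benzyloxy analogue with a six-membered amine ring, gives 8080 nM in this assay.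

Compound 3 `COC(=O)c1cccc(COc2ccc(OCCOCCNC3CCCC3)cc2)c1` has not been measured in this assay. It differs from compound 1 only by methyl in place of hydrogen on an oxygen next to a carbonyl group. Within the data shown here, no pair of measured compounds that differ in one place is available, so the size of this step cannot be read from the data; with compound 1 known only as a limit, the true starting point is itself uncertain.

Compound 3 is expected to reach 30000 nM in this assay, with a range of 8000 nM to 100000 nM. The step of an at least 3.3-fold lower number from compound 1 to compound 3 (0.52 log units; beyond the scatter) is thus expected to run downward, toward stronger inhibition, and beyond the usual scatter, though a result that is again only a limit remains a real possibility for compound 3.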

Compound 3, half-maximal inhibitory concentration: 45500 nM
Compound 3: the middle estimate sits 1.5-fold (0.18 log units) below what was measured, within the range that was stated.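

The change from carboxy to methoxycarbonyl gives an at least 2.1-fold lower number from compound 1 to compound 3 (0.34 log units; beyond the scatter), so in this assay this position on the terminal ring responds to a single added methyl, and the series now has a measured value with the shared core and the five-membered amine ring held constant. In this assay compound 1 gives > 100000 nM, which is a limit of the assay and not a number. The true size of the step therefore remains unknown and may be larger than printed, because one end of it rests on a limit: the limit of > 100000 nM in this assay, at which 1 of the 3 values shown sits.

Compound 2 differs from compound 3 in more than one place, so the separate contributions of its amine ring and its benzyloxy end cannot be read from this pair. As far as these compounds go, it also remains open whether the step follows from the added methyl itself or from the removal of the free acid hydrogen, a question that an ethyl ester or a primary amide at the same position would help to separate.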